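A hydroxy to acetamido swap in compound 2

The source may report more compounds than this note shows. Statements on the series, on what has been measured and on what is new or still open speak of the compounds shown alone.

Compound 1 `COc1cc2c(cc1CCC(C)C)C(=O)C[C@@H](c1ccc(O)cc1)O2`: 75%
Compound 2 `COc1ccc([C@@H]2C/C(=N/OCc3cn(-c4ccc(O)cc4)nn3)c3cc(CC=C(C)C)c(OC)cc3O2)cc1`: 52%
Compound 3 `COc1cc2c(cc1CC=C(C)C)/C(=N/O)C[C@@H](c1ccc(O)cc1)O2`: 80%

All three compounds were measured in a functional assay on A549 cells (Homo sapiens) for inhibition, read by sulforhodamine B assay, with a stated time of 48 h, tested at 50 uM; a higher number here means more inhibition of growth at the concentration tested, a lower number less inhibition of growth. Compound 2 stands lowest of the three, at 52%. Compound 1 gives 75% and compound 3 gives 80%. The gap from compound 2 to each of these two lies beyond the scatter. Compound 1 and compound 3 lie within the scatter of each other.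

The next compound to be measured is compound 4 `COc1ccc([C@@H]2C/C(=N/OCc3cn(-c4ccc(NC(C)=O)cc4)nn3)c3cc(CC=C(C)C)c(OC)cc3O2)cc1`, which departs from compound 2 in one place: acetamido in place of hydroxy on an aromatic carbon. In words, acetamido stands in place of hydroxy on an aromatic carbon, para to a large group, so that 4-hydroxyphenyl becomes 4-acetamidophenyl.

Among the compounds with values here, no pair of measured compounds differs in one place, so the data give no direct measure of what such a change does. Within the data shown here, compound 2, at 52%, is the only measured compound that shares the larger frame of compound 4, and the expectation stays anchored to it. In this assay the estimated step is a number 4 percentage points lower from compound 2 to compound 4 (within the scatter), a small fall that is expected to remain within the scatter. For compound 4 the expected value is 48%, with an estimated range from 32% to 65%.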

Compound 4, percent growth inhibition at one concentration: 19%
The estimate for compound 4 lay 29 percentage points above the measured number, and the stated range ends above it.
By their numbers in this assay, from the lowest: compound 4; then compound 2; then compounds 1 and 3 (each within the scatter of the next).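

Within the data shown here, this is the first one-place comparison in the set: in this assay, placing acetamido instead of hydroxy on this aromatic carbon, para to a large group, gives a number 33 percentage points lower from compound 2 to compound 4 (beyond the scatter), with the rest of the structure unchanged. The position is therefore not indifferent to the group it carries, and the change from 4-hydroxyphenyl to 4-acetamidophenyl matters here even though the two groups are counted alike for hydrogen-bond donors and acceptors and differ in their heavy atoms. Nothing available explains why the number falls with this change.

With only hydroxy and acetamido shown at this position, the compounds leave open whether the fall follows from the loss of hydroxy or from the arrival of acetamido, and an amine, a methoxy group or a longer acyl chain on the same carbon would help to separate the two. Among these compounds, they also leave open whether the same swap would give a step of similar size on a different frame, since this single pair is the only reading of the change.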